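Hydroxy on the thione analogue: what compound 4 might give

This account rests on a few compounds, and the source may have more. Where it says the series, first, only, none or still open, it means among the compounds named here.

Of the compounds shown here, three sharing one core have been measured in a functional assay, with a stated time of 20 min, tested at 50 uM; a lower number here means a weaker effect, a higher number a stronger effect of the compound at the concentration tested. Compound 1 `COc1cc(/C=C/C(=O)C2=C(/C=C/c3ccc(O)c(OC)c3)NC(=O)NC2c2ccccc2O)ccc1O` gives 88% and compound 2 `COc1cc(/C=C/C(=O)C2=C(/C=C/c3ccc(O)c(OC)c3)NC(=O)NC2c2ccc(O)cc2)ccc1O` gives 86.2%; the step of a number 1.8 percentage points lower from compound 1 to compound 2 (within the scatter) shows that moving the hydroxy on that ring changes nothing beyond the scatter. Compound 3 `COc1cc(/C=C/C(=O)C2=C(/C=C/c3ccc(O)c(OC)c3)NC(=S)NC2c2ccccc2)ccc1O`, the thione with an unsubstituted phenyl on the saturated ring carbon, gives 50.4%, the lowest of the three numbers, beyond the scatter below both compound 1 and compound 2. Compound 3 differs from compound 1 in two places at once, so its gap to compound 1 cannot be assigned to either change.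

Compound 4 `COc1cc(/C=C/C(=O)C2=C(/C=C/c3ccc(O)c(OC)c3)NC(=S)NC2c2ccccc2O)ccc1O` differs from compound 3 by hydroxy in place of hydrogen on an aromatic carbon. Among the compounds with values here, no measured step bears directly on this change: the only step at hand, from compound 1 to compound 2, exchanges one hydroxy position for another and lies within the scatter. The two hydroxy-bearing ureas sit high and the bare-phenyl thione sits low, but nothing separates the thione from the hydroxy in that comparison. Compound 4 is therefore expected near compound 3 with a modest upward lean, an estimated a number 9.6 percentage points higher from compound 3 to compound 4 (within the scatter), giving an estimate of 60% with a range from 40% to 80%.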

Compound 4, a percentage reported as activity, at one concentration (the size of the read-out at that concentration, not a potency): 88.5%
For compound 4 the middle estimate is 28.5 percentage points below the measured one; the measured number lies above the stated range.
By their numbers in this assay, from the lowest: compound 3; then compounds 2, 1 and 4 (each within the scatter of the next).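

In this assay the change from phenyl to 2-hydroxyphenyl gives a number 38.1 percentage points higher from compound 3 to compound 4 (beyond the scatter) as the only difference between the two structures, whereas the earlier step moved a hydroxy from one place to another and so could not show what its presence alone is worth. The low value of compound 3 therefore goes with the bare phenyl and not with the thione alone in this comparison: compound 1 at 88% and compound 4 at 88.5% lie within the scatter of each other. Nothing at hand explains the size of this step.

The compounds shown leave open whether the hydroxy itself is needed at this place, or whether a methoxy, an amine or a fluorine on the same aromatic carbon would give a similar value. They also leave open whether the 4-hydroxyphenyl group, seen here only with the carbonyl, would match the 2-hydroxyphenyl group on the thione, and whether a bare phenyl with the carbonyl would fall as low as compound 3.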